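Ring-Nitrogen Methylation Across Two Related Cores

The compounds below may be only part of what the source reports. "The series", "measured", "known", "first", "only" and "open" are said of these compounds alone.

The measured compounds:
Compound 1, `COc1cc2c(cc1C)NC(=O)/C2=C/c1c(Cl)n(C)c2cc(C)c(OC)cc12`, gives 22400 nM.
Compound 2, `COc1cc2c(cc1C)N(C)C(=O)/C2=C/c1c(Cl)n(C)c2cc(C)c(OC)cc12`, gives 35500 nM.
Compound 3, `CN(C)c1ccc2[nH]c(Cl)c(/C=C3/C(=O)Nc4ccc(O)cc43)c2c1`, gives 8910 nM.

These values come from a functional assay on cells (Cancer cell lines, Homo sapiens) for inhibition, with a stated time of 48 h; on this read-out lower numbers stand for stronger inhibition of growth and higher numbers for weaker inhibition of growth. Compound 1 and compound 2 share a core and differ by one change, (methyl in place of hydrogen on an amide-type nitrogen in a ring), and that change produced a 1.6-fold higher number from compound 1 to compound 2 (0.20 log units; within the scatter). Compound 3 has a different core, and how its core differs from that of compound 1 is not broken down here; its value stands lowest of the three measured numbers, beyond the scatter from both compound 1 and compound 2.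

The unmeasured compound 4, `CN(C)c1ccc2[nH]c(Cl)c(/C=C3/C(=O)N(C)c4ccc(O)cc43)c2c1`, carries the same change relative to compound 3, namely (methyl in place of hydrogen on an amide-type nitrogen in a ring). The place of the change is described identically in both pairs, so it is the same change applied to a second core. Resting on compound 1 to compound 2, where a 1.6-fold higher number from compound 1 to compound 2 (0.20 log units; within the scatter) was seen, a step of comparable size is expected from compound 3 to compound 4 in this assay, a 1.5-fold higher number from compound 3 to compound 4 (0.16 log units; within the scatter). Compound 4 is therefore estimated at 13000 nM, with a range from 6000 nM to 30000 nM.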

Compound 4, concentration for 50% growth inhibition: 12900 nM
Estimate against measurement, compound 4: 1.0-fold (0.00 log units) above, and the stated range covers the measured number.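

In this assay, putting a methyl in place of the hydrogen on the amide-type nitrogen in a ring gave a 1.4-fold higher number from compound 3 to compound 4 (0.16 log units; within the scatter), and set beside the earlier step on the other core, the result reads: the same change on two cores in this assay, a 1.6-fold higher number (0.20 log units; within the scatter) from compound 1 to compound 2 and a 1.4-fold higher number (0.16 log units; within the scatter) from compound 3 to compound 4, 1.1-fold (0.04 log units) apart, within the scatter of two such steps. On these two cores, then, the change carried over with a step of like size, and on neither core did it move the number beyond the scatter. This does not show that either step is a real loss of growth inhibition, and two pairs do not establish that the same would hold on a further core in this series.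

The compounds shown leave open whether anything larger than methyl on this nitrogen, such as an ethyl group, a longer chain, or a chain ending in an amine or a carboxylic acid, would stay as close to the parent compound. They also leave open how such groups would behave on each of the two cores.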